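Swapping chloro for methoxy on the benzyl ring

The compounds below may be only part of what the source reports. "The series", "measured", "known", "first", "only" and "open" are said of these compounds alone.

Of the compounds shown here, three sharing one core have been tested in a functional assay on HeLa cells (Homo sapiens) for cytotoxicity, read by MTT assay, with a stated time of 48 h; on this read-out higher numbers stand for weaker inhibition and lower numbers for stronger inhibition. Compound 1 `N#Cc1ccc(Cn2cc(COc3ccc4c(=O)ccoc4c3)nn2)cc1` gives only a limit in this assay, > 100000 nM, so no number is known for it. Compound 2 `O=c1ccoc2cc(OCc3cn(Cc4ccccc4Br)nn3)ccc12` gives 14500 nM in this assay. Compound 3 `O=c1ccoc2cc(OCc3cn(Cc4ccc(Cl)cc4)nn3)ccc12` gives 37600 nM in this assay, the highest of the two numbers shown; its nearest neighbour is compound 2, and the step of a 2.6-fold higher number from compound 2 to compound 3 (0.41 log units; beyond the scatter) came with a 4-chlorophenyl in place of 2-bromophenyl on a saturated chain carbon bound to an aromatic nitrogen. The step of an at least 2.6-fold lower number from compound 1 to compound 3 (0.42 log units; beyond the scatter) came with chloro in place of cyano on an aromatic carbon.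

Compound 4 `COc1ccc(Cn2cc(COc3ccc4c(=O)ccoc4c3)nn2)cc1` is not yet measured. It differs from compound 3 by methoxy in place of chloro on an aromatic carbon. Among the compounds with values here, the only earlier change at that same aromatic carbon is the one from compound 1 to compound 3, which starts from a limit and so gives only a lower bound on its size. Within the data shown here, no measured step introduces a methoxy, so the direction of this change cannot be read from the data. The step of a 1.1-fold higher number from compound 3 to compound 4 (0.03 log units; within the scatter) is therefore expected to be small, likely within the scatter, in either direction. Compound 4 is estimated at 40000 nM in this assay, with a range from 13000 nM to 120000 nM.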

Compound 4, half-maximal inhibitory concentration: 14400 nM
For compound 4 the middle estimate is 2.8-fold (0.44 log units) above the measured one; the range from low to high includes it.
By their numbers in this assay, from the lowest: compounds 4 and 2 (each within the scatter of the next); then compound 3. At a limit, above all of these: compound 1.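

In this assay, within the data shown here, the step of a 2.6-fold lower number from compound 3 to compound 4 (0.42 log units; beyond the scatter), with methoxy in place of chloro, is the first change at this aromatic carbon with a real number at both ends, so it gives that change both a direction and a size. A second step, a 1.0-fold lower number from compound 2 to compound 4 (0.00 log units; within the scatter), shows that the 4-methoxybenzyl compound and the 2-bromobenzyl compound cannot be told apart here, even though their groups differ in kind and in where they sit on the ring. The step of an at least 6.9-fold lower number from compound 1 to compound 4 (0.84 log units; beyond the scatter), with methoxy in place of cyano, gives only a bound, and what it rests on is a limit, that of compound 1: the limit of > 100000 nM in this assay, at which 1 of the 4 values shown sits.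

The compounds shown leave open whether the lower number belongs to methoxy in particular or would also come with another group on this carbon, such as a hydroxyl, an amine or a longer chain like ethoxy. They also leave open whether methoxy would give a different number at the place the bromine holds in compound 2, and nothing here explains why the number changes.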